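This account rests on a few compounds, and the source may have more. Where it says the series, first, only, none or still open, it means among the compounds named here.

Measured compounds in a functional assay on A549 cells (Homo sapiens) for antiproliferative activity, read by MTT assay, with a stated time of 48 h; a higher number here means a weaker inhibitor, a lower number a stronger inhibitor:
Compound 1 `Cn1c(N)c(-c2nc3ccccc3[nH]2)c2nc(C#N)c(C#N)nc21`: > 50000 nM
Compound 2 `CCN(CC)CCn1c(N)c(-c2nc3ccccc3[nH]2)c2nc(C#N)c(C#N)nc21`: > 50000 nM
Compound 3 `N#Cc1nc2c(-c3nc4ccccc4[nH]3)c(N)n(CCO)c2nc1C#N`: > 50000 nM

Each of these entries is a limit of the assay and not a number. Compound 3 stands at the limit of > 50000 nM in this assay, at which 3 of the 3 values shown sit. From the compounds shown here alone, its exact potency therefore remains unknown, and it cannot be ranked against compound 1 or compound 2.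

Compound 4 `N#Cc1nc2c(-c3nc4ccccc4[nH]3)c(N)n(CCCO)c2nc1C#N` keeps the core of compound 3 and changes only the side chain on the aromatic nitrogen. It carries hydroxymethyl in place of hydroxy on a saturated chain carbon, two bonds along the chain from an aromatic nitrogen. The same difference reads as 2-hydroxyethyl to 3-hydroxypropyl.

The measured steps closest to this change are a step that the two limits leave unreadable from compound 1 to compound 3 and a step that the two limits leave unreadable from compound 2 to compound 3. The remaining measured step is a step that the two limits leave unreadable from compound 1 to compound 2. None of the three has a readable size, so none gives a direction for the longer chain. In this assay, no step beyond the scatter is expected, and compound 4 is expected to stay at the limit. The expected step is a step that the limit leaves unreadable from compound 3 to compound 4. Compound 4 is estimated at 60000 nM, with an expected range from 30000 nM to 120000 nM.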

Compound 4, half-maximal inhibitory concentration: > 50000 nM
Compound 4 gave a limit, no number; the forecaster's own chance of this, stated with the estimate: 85%; the middle value does not contradict the limit.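

In this assay compound 4 gives > 50000 nM, which is a limit and not a number. Going by these compounds alone, its steps to compound 1, compound 2 and compound 3 therefore cannot be read, and no new step follows from this result. The compounds shown leave open how potent any of them is and whether changing the side chain on the aromatic nitrogen alters potency at all: the limit of > 50000 nM in this assay, at which 4 of the 4 values shown sit.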